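A few compounds are considered here, and "the series" means these few. Any claim that something is new, unique, unknown or untested is made for them only; others in the source may bear on it.

Of the compounds shown here, two have been measured. Compound 1, with the structure `COc1ccc(C2=Nn3c(nnc3-c3cc(-c4ccc(F)cc4)n[nH]3)SC2C)cc1`, and compound 2, with the structure `CC1Sc2nnc(-c3cc(-c4ccccc4)n[nH]3)n2N=C1c1ccccc1`, were both tested in a functional assay on CAL-33 cells (Homo sapiens) for inhibition; a higher number here means a weaker inhibitor of growth, a lower number a stronger inhibitor of growth. In this assay compound 1 gives 29500 nM. In this assay compound 2 gives 34100 nM. Among the compounds with values here, of the two numbers, the one for compound 2 sits next to that of compound 1 at a gap that lies within the usual scatter of repeated measurements, so the two cannot be told apart on these data, and neither can be called the stronger inhibitor of growth.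

Compound 3, with the structure `CC1Sc2nnc(-c3cc(-c4ccc(F)cc4)n[nH]3)n2N=C1c1ccccc1`, differs from compound 2 in one place: fluoro in place of hydrogen on an aromatic carbon. Compound 1 already carries a 4-fluorophenyl, but it also differs from compound 2 elsewhere, so no clean comparison of this single change is available. With nothing beyond the scatter separating compound 1 from compound 2, the step from compound 2 to compound 3 is expected to stay within the scatter, amounting to a 1.1-fold lower number from compound 2 to compound 3 (0.03 log units; within the scatter). Compound 3 is therefore estimated at 32000 nM, with a range from 12000 nM to 85000 nM.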

Compound 3, concentration for 50% growth inhibition: 36300 nM
Estimate against measurement, compound 3: 1.1-fold (0.05 log units) below; low and high end bracket the measured number.
By their numbers in this assay, from the lowest: compounds 1, 2 and 3 (each within the scatter of the next).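

In this assay, the change from phenyl to 4-fluorophenyl, with the fluoro para to a large group, gives a 1.1-fold higher number from compound 2 to compound 3 (0.03 log units; within the scatter). Within the data shown here, this is the first direct reading of this change, and it shows that compounds with hydrogen and fluoro at this place cannot be told apart in this test. The comparison of hydrogen in place of methoxy on an aromatic carbon gives a 1.2-fold higher number from compound 1 to compound 3 (0.09 log units; within the scatter), so compound 1 and compound 3 cannot be told apart either, and nothing measured alongside these compounds bears on this result.

Fluoro and hydrogen are both small, so it remains open whether a different kind of group at this place on the ring, such as an amine, a carboxylic acid or a longer chain, would shift the number beyond the scatter. From the compounds shown here alone, it is also open whether replacing the methoxy with one of these groups would do so, and whether any such change would hold in a test other than this growth read-out.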